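Bromocrotonyl in Place of Bromopropanoyl on the Amide

The source may hold more compounds than are shown below. What is called first, only, known or untested is meant among the compounds shown, and "the series" means these compounds.

Measured so far:
- compound 1, `COc1ccc(CN(C(=O)C(C)Br)c2cc(OC)c(OC)c(OC)c2)cc1O`, 160 nM
- compound 2, `COc1cc(NCc2ccc(Cl)cc2)cc(OC)c1OC`, > 80000 nM
- compound 3, `C/C=C/C(=O)N(Cc1ccc(OC)c(N)c1)c1cc(OC)c(OC)c(OC)c1`, 310 nM

All three share a trimethoxyphenyl-bearing core and were tested in a functional assay on KYSE-450 cells (Homo sapiens) for inhibition, read by MTT assay, with a stated time of 48 h; on this read-out lower numbers stand for stronger inhibition and higher numbers for weaker inhibition. Compound 1 has the lowest of the two numbers recorded. Compound 3 stands nearest, with a number that lies within the usual scatter of compound 1, so the two cannot be ranked against each other. Compound 2 is different: for compound 2 this assay gives a limit rather than a number, namely (the limit of > 80000 nM in this assay, at which 1 of the 3 values shown sits). Among the measured compounds shown here, that limit says only that compound 2 shows no measurable inhibition up to where the assay stops.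

The new compound 4, `COc1ccc(CN(C(=O)/C=C/CBr)c2cc(OC)c(OC)c(OC)c2)cc1O`, is not yet measured. It differs from compound 1 in one place: 3-bromoprop-1-en-1-yl in place of 1-bromoethyl on a carbonyl carbon. The acyl group on the amide nitrogen thus grows by one carbon and gains a double bond while keeping its bromine.

Since compound 3 already gives 310 nM with an unsaturated acyl group and sits within the scatter of compound 1, no step beyond the scatter is expected from compound 1 to compound 4 in this assay. This expectation means a step of a 1.2-fold lower number from compound 1 to compound 4 (0.09 log units; within the scatter). Compound 4 is therefore estimated at 130 nM, with a likely range from 40 nM to 450 nM.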

Compound 4, half-maximal inhibitory concentration: 100 nM
The estimate for compound 4 lay 1.3-fold (0.11 log units) above the measured number; measured number inside the range.
By their numbers in this assay, from the lowest: compounds 4, 1 and 3 (each within the scatter of the next, the first and the last beyond it). At a limit, above all of these: compound 2.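

This is the first pair shown that differs only in the group on the carbonyl carbon whose other neighbour is the amide-type nitrogen, so it isolates the effect of this one change. In this assay, 3-bromoprop-1-en-1-yl in place of 1-bromoethyl gives a 1.6-fold lower number from compound 1 to compound 4 (0.20 log units; within the scatter), which means that the two compounds cannot be ranked against each other and that this place accepts a group with one more carbon and a double bond without a change beyond the scatter. Nothing measured here accounts for why the two groups read alike.

Whether the bromine itself matters stays open, as both groups carry it and no pair shown differs by that atom alone. Also open, from the compounds shown here alone, is how a chlorine in place of the bromine, an amine at the end of the chain, or a longer chain on this carbonyl carbon would read in this assay.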